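Removing the trifluoromethyl from the benzamide of compound 1

A few compounds are considered here, and "the series" means these few. Any claim that something is new, unique, unknown or untested is made for them only; others in the source may bear on it.

For the measured compounds named here, compound 1 `COc1cc(-c2nn(-c3cccc(NC(=O)c4cccc(C(F)(F)F)c4)c3)cc2-c2ccncc2)ccc1Cl` gives 2450 nM in a functional assay on 786-0 cells (Homo sapiens) for inhibition, read by sulforhodamine B assay, with a stated time of 48 h (on this read-out lower numbers stand for stronger inhibition of growth and higher numbers for weaker inhibition of growth), the highest of the three numbers so far; compound 2 `COc1cc(-c2nn(-c3cccc(NC(=O)Nc4cccc(C(F)(F)F)c4)c3)cc2-c2ccncc2)ccc1Cl` gives 1280 nM and compound 3 `O=C(Nc1cccc(-n2cc(-c3ccncc3)c(-c3ccc(Cl)c(O)c3)n2)c1)Nc1cc(C(F)(F)F)cc(C(F)(F)F)c1` gives 1170 nM. Going by the values given here, the only single-point step, a 1.9-fold lower number from compound 1 to compound 2 (0.28 log units; within the scatter), lies within the scatter. Compound 4 `COc1cc(-c2nn(-c3cccc(NC(=O)c4ccccc4)c3)cc2-c2ccncc2)ccc1Cl` differs from compound 1 by hydrogen in place of trifluoromethyl on an aromatic carbon. Among the compounds with values here, no measured step removes a trifluoromethyl, so nothing measured bears on it directly; compound 3 carries two such groups and compound 1 and compound 2 one each, but these pairs differ elsewhere too. Compound 4 is expected to give 3500 nM, between 1200 nM and 10000 nM, a step of a 1.4-fold higher number from compound 1 to compound 4 (0.15 log units; within the scatter), with the direction uncertain.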

Compound 4, concentration for 50% growth inhibition: 1520 nM
Beside the measured number, compound 4's estimate is 2.3-fold (0.36 log units) above it; the measured number falls inside the stated range.
By their numbers in this assay, from the lowest: compounds 3, 2, 4 and 1 (each within the scatter of the next, the first and the last beyond it).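

In this assay hydrogen in place of trifluoromethyl on this aromatic carbon gives a 1.6-fold lower number from compound 1 to compound 4 (0.21 log units; within the scatter) and so shows that, on the benzamide, this group can go without a step beyond the scatter. Phenyl in place of (3-(trifluoromethyl)phenyl)amino on the carbonyl carbon gives a 1.2-fold higher number from compound 2 to compound 4 (0.07 log units; within the scatter) and so also stays within the scatter. Nothing available explains either result.

Going by these compounds, whether hydrogen in place of trifluoromethyl reads the same on compound 2 remains open. Also open, on these data alone, is whether a nitrile or a carboxylic acid on this aromatic carbon would give a step beyond the scatter.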